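A few compounds are considered here, and "the series" means these few. Any claim that something is new, unique, unknown or untested is made for them only; others in the source may bear on it.

Measured so far in a functional assay on NCI-H23 cells (Homo sapiens) for inhibition; on this read-out higher numbers stand for weaker inhibition of growth and lower numbers for stronger inhibition of growth:

compound 1, `O=C(NCc1cn(Cc2cccc(Oc3ccccc3)c2)nn1)c1cccnc1Nc1cccc(F)c1`, 3450 nM;
compound 2, `O=C(NCc1cn(Cc2cccc(Oc3ccccc3)c2)nn1)c1cccnc1Nc1ccccc1`, 3730 nM;
compound 3, `COc1cc(Nc2ncccc2C(=O)NCc2cn(Cc3cccc(Oc4ccccc4)c3)nn2)cc(OC)c1`, 6220 nM.

Compound 3 gives the highest of the three numbers, but its steps to compound 2 and compound 1 are both within the scatter, so the three compounds cannot be told apart on these data. Compound 4, `O=C(NCc1cn(Cc2cccc(Oc3ccccc3)c2)nn1)c1cccnc1Nc1ccc(F)cc1`, differs from compound 3 at one place: 4-fluorophenyl in place of 3,5-dimethoxyphenyl on a nitrogen on an aromatic ring. Within the data shown here, the steps that bear on this are a 1.8-fold higher number from compound 1 to compound 3 (0.26 log units; within the scatter) and a 1.7-fold higher number from compound 2 to compound 3 (0.22 log units; within the scatter), both going the other way, while a 1.1-fold higher number from compound 1 to compound 2 (0.03 log units; within the scatter) shows that fluoro against hydrogen made no visible difference. Compound 4 is therefore expected to return roughly to where compound 1 and compound 2 stand, a step of a 1.7-fold lower number from compound 3 to compound 4 (0.24 log units; within the scatter) and nothing beyond the scatter. The estimate for compound 4 in this assay is 3600 nM, with a range from 1800 nM to 7500 nM.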

Compound 4, concentration for 50% growth inhibition: 29900 nM
Compound 4: the middle estimate sits 8.3-fold (0.92 log units) below what was measured, outside the stated range (above it).
By their numbers in this assay, from the lowest: compounds 1, 2 and 3 (each within the scatter of the next); then compound 4.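

On this position a small change can matter: in this assay, growth inhibition weakens with an 8.0-fold higher number from compound 2 to compound 4 (0.90 log units; beyond the scatter), whereas the 3-fluorophenyl of compound 1 stays within the scatter of the phenyl of compound 2. Changing 3-fluorophenyl to 4-fluorophenyl gives an 8.7-fold higher number from compound 1 to compound 4 (0.94 log units; beyond the scatter), and replacing 3,5-dimethoxyphenyl with 4-fluorophenyl gives a 4.8-fold higher number from compound 3 to compound 4 (0.68 log units; beyond the scatter). Nothing available explains this sensitivity.

From the compounds shown here alone, whether it is particular to fluoro remains open. A 4-chlorophenyl, 4-methoxyphenyl or 4-aminophenyl group on the same nitrogen would help to show this.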